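The compounds below may be only part of what the source reports. "The series", "measured", "known", "first", "only" and "open" are said of these compounds alone.

Series notes. In an assay on isolated protein for inhibition of Rho-associated protein kinase 2 (Homo sapiens), read by radiometric assay (on this read-out lower numbers stand for stronger inhibition and higher numbers for weaker inhibition), compound 1 `CCCCCCOC(=O)c1cccc(-c2cc(C(=O)Nc3ccncc3)ccc2CN)c1` gives 22 nM, compound 2 `NCc1ccc(C(=O)Nc2ccncc2F)cc1-c1cccc(C(=O)OCC2CC2)c1` gives 2.7 nM, and compound 3 `NCc1ccc(C(=O)Nc2ccncc2F)cc1-c1cccc(C(=O)OCC2CCCO2)c1` gives 2.5 nM. Compound 3 carries the lowest of the three numbers; compound 2 sits within the scatter of it, while compound 1 lies beyond the scatter. Compound 4 `NCc1ccc(C(=O)Nc2ccncc2F)cc1-c1cccc(C(=O)OCC2CCCCO2)c1` is not yet measured and differs from compound 3 by oxan-2-yl in place of oxolan-2-yl on a saturated chain carbon bound to an oxygen next to a carbonyl group. For the measured compounds named here, the one measured step bearing on this position is a 1.1-fold lower number from compound 2 to compound 3 (0.03 log units; within the scatter), a swap of the ring on the saturated chain carbon bound to an oxygen next to a carbonyl group that moved nothing beyond the scatter. On that evidence no step beyond the scatter is expected in this assay for compound 4, with no change at the digits printed from compound 3 to compound 4 (within the scatter). Compound 4 is estimated at 2.5 nM, range 1.2 nM to 5.5 nM.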

Compound 4, half-maximal inhibitory concentration: 12 nM
Compound 4: middle estimate off by 4.8-fold (0.68 log units), on the low side; measured number outside the range, above it.
By their numbers in this assay, from the lowest: compounds 3 and 2 (each within the scatter of the next); then compounds 4 and 1 (each within the scatter of the next).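

In this assay the ring on the saturated chain carbon bound to an oxygen next to a carbonyl group is not a free choice: oxan-2-yl in place of oxolan-2-yl gives a 4.8-fold higher number from compound 3 to compound 4 (0.68 log units; beyond the scatter) in this series. Cyclopropyl and oxolan-2-yl read alike, yet the oxan-2-yl swap also gives a 4.4-fold higher number from compound 2 to compound 4 (0.65 log units; beyond the scatter) from that side. No measurement at hand explains this shift.

Open, as far as these compounds go, is whether ring size or the ring oxygen governs the step; cyclopentyl and cyclohexyl on the same carbon would separate the two. Also open, from the compounds shown here alone, is how a ring amine such as piperidin-2-yl would read here.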